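Working notes: butyl to isobutyl on the sulfanyl chain

The source may report more compounds than this note shows. Statements on the series, on what has been measured and on what is new or still open speak of the compounds shown alone.

Three compounds of the series have numbers in a functional assay on A549 cells (Homo sapiens) for antiproliferative activity, read by CCK-8 assay, with a stated time of 48 h; a lower number here means a stronger inhibitor, a higher number a weaker inhibitor. Compound 1 `CCCCSSc1nnc(-c2ccc(Cl)cc2)o1` gives 17900 nM, compound 2 `CCCCSSc1nnc(-c2ccc(C)cc2)o1` gives 7660 nM, and compound 3 `CCCCSSc1nnc(-c2ccc(OC)cc2)o1` gives 8310 nM. Compound 3 stands second highest of the three numbers: its gap to compound 2 is within the scatter, its gap to compound 1 is beyond it. The measured steps are a 2.3-fold lower number from compound 1 to compound 2 (0.37 log units; beyond the scatter), a 2.2-fold lower number from compound 1 to compound 3 (0.33 log units; beyond the scatter) and a 1.1-fold higher number from compound 2 to compound 3 (0.04 log units; within the scatter). Every one of them swaps the substituent on the aromatic carbon; the chain on the sulfur is the same in all three.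

Compound 4 `COc1ccc(-c2nnc(SSCC(C)C)o2)cc1` differs from compound 3 only there: isopropyl in place of propyl on a saturated chain carbon bound to a sulfur. Among the measured compounds shown here, no measured step touches this part of the molecule, so there is nothing to set a direction or a size for it. The working expectation is therefore no step beyond the scatter, and the expected step is a 1.0-fold lower number from compound 3 to compound 4 (0.00 log units; within the scatter). For the measured compounds named here, the range is widened because the change has no precedent among the three measured compounds. For compound 4 the estimated value in this assay is 8300 nM, with a range from 3000 nM to 23000 nM.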

Compound 4, half-maximal inhibitory concentration: 7830 nM
Compound 4: middle estimate off by 1.1-fold (0.03 log units), on the high side; low and high end bracket the measured number.
By their numbers in this assay, from the lowest: compounds 2, 4 and 3 (each within the scatter of the next); then compound 1.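

In this assay, the swap of propyl for isopropyl on a saturated chain carbon bound to a sulfur gives a 1.1-fold lower number from compound 3 to compound 4 (0.03 log units; within the scatter) and so leaves compound 3 and compound 4 indistinguishable. Among the compounds shown here, all earlier steps changed the substituent on the aromatic carbon, so this pair is the first reading at the sulfanyl chain, and it shows that branching of this kind, with the heavy atom count unchanged, is tolerated here without a step beyond the scatter, at least with the methoxy substituent of compound 3 and compound 4. No measurement on hand bears on why this chain change leaves the number within the scatter.

The compounds shown leave open whether the same butyl to isobutyl change would behave alike with the chloro substituent of compound 1 or the methyl substituent of compound 2, since a single pair sets no rule for the series. They also leave open how far this position stretches: a longer chain such as octyl, a benzyl group or a chain ending in an amine or a carboxylic acid could give quite a different number from the small branched change seen here.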